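The compounds below may be only part of what the source reports. "The series", "measured", "known", "first", "only" and "open" are said of these compounds alone.

Working notes on the series. In a functional assay on HeLa cells (Homo sapiens) for cytotoxicity, read by CCK-8 assay, with a stated time of 24 h (on this read-out lower numbers stand for stronger inhibition and higher numbers for weaker inhibition), compound 1 `C/C(=C\c1ccc(-c2ccc(C)cc2)o1)C(N)=O` gives 4590 nM. Compound 2 `C/C(=C\c1ccc(-c2ccc(F)cc2)o1)C(N)=O` differs from compound 1 by fluoro in place of methyl on an aromatic carbon, and in this assay compound 2 gives 2030 nM. The measured step is a 2.3-fold lower number from compound 1 to compound 2 (0.35 log units; beyond the scatter).

Compound 3 `C/C(=C\c1cc(-c2ccc(C)cc2)cs1)C(N)=O` rests on another core; the difference between its core and the core of compound 1 is not broken down here. In this assay compound 3 gives > 50000 nM, which is a limit of the assay and not a number. This is the limit of > 50000 nM in this assay, at which 1 of the 3 values shown sits.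

Compound 4 `C/C(=C\c1cc(-c2ccc(F)cc2)cs1)C(N)=O` has not yet been measured. It differs from compound 3 by fluoro in place of methyl on an aromatic carbon. The place is the same word for word as in the change from compound 1 to compound 2, so this is the same change, made for the second time among the compounds shown.

The step to expect for compound 4 rests on the one measured pairing: the change from compound 1 to compound 2 gave a 2.3-fold lower number from compound 1 to compound 2 (0.35 log units; beyond the scatter), a modest movement. Applied to compound 3, whose result is only a limit, a step of that size is expected to leave the result at or close to the limit, so the estimated step is an at least 1.2-fold lower number from compound 3 to compound 4 (0.09 log units; that floor lies within the scatter). Compound 4 is expected at 40000 nM, with a range from 15000 nM to 100000 nM, and a reported limit rather than a number is the more likely outcome.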

Compound 4, half-maximal inhibitory concentration: 20800 nM
Compound 4: middle estimate off by 1.9-fold (0.28 log units), on the high side, within the range that was stated.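

In this assay, fluoro in place of methyl on an aromatic carbon gives an at least 2.4-fold lower number from compound 3 to compound 4 (0.38 log units; beyond the scatter), so the change that lowered the number on the core of compound 1 also lowers it on the core of compound 3. Set side by side, the two pairs agree in direction, but their sizes cannot be fully compared: the same change on two cores in this assay, a 2.3-fold lower number (0.35 log units; beyond the scatter) from compound 1 to compound 2 and an at least 2.4-fold lower number (0.38 log units; beyond the scatter) from compound 3 to compound 4; the limit leaves it open whether they differ The value of compound 3, > 50000 nM, is a limit of the assay and not a number, so the step on this core is a floor rather than a measured size, and two pairs show nothing about cores beyond these two: the limit of > 50000 nM in this assay, at which 1 of the 4 values shown sits.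

The compounds shown leave open whether a group other than methyl or fluoro, such as chloro, methoxy or an amine, on the same aromatic carbon would move the number in the same direction on both cores. They also leave open whether the change would hold on a third core, and how either pair would respond if a carboxylic acid or a longer chain took the place of the amide.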